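The source may report more compounds than this note shows. Statements on the series, on what has been measured and on what is new or still open speak of the compounds shown alone.

Compound 1 `Nc1ccc(-c2cc(=O)c3c(N)c(F)c(N)c(F)c3o2)cc1F`: 7.7 nM
Compound 2 `CN(C)c1c(F)c(N)c2c(=O)cc(-c3ccc(N)c(F)c3)oc2c1F`: 39 nM

In a functional assay on MCF7 cells (Homo sapiens) for cytotoxicity, read by neutral red uptake, with a stated time of 3 days (on this read-out higher numbers stand for weaker inhibition and lower numbers for stronger inhibition), compound 1 gives 7.7 nM and compound 2 gives 39 nM. Among the compounds with values here, compound 2 holds the higher of the two numbers, and the only measured step, a 5.1-fold higher number from compound 1 to compound 2 (0.70 log units; beyond the scatter), lies beyond the scatter. Compound 3 `CCC(=O)OCc1c(F)c(N)c2c(=O)cc(-c3ccc(N)c(F)c3)oc2c1F` differs from compound 2 by (propanoyloxy)methyl in place of dimethylamino on an aromatic carbon. Within the data shown here, no measured step carries this change; the one known step, a 5.1-fold higher number from compound 1 to compound 2 (0.70 log units; beyond the scatter), exchanged one substituent of the shared core for another and gave a modest rise. The step from compound 2 to compound 3 is therefore expected to be small, a 1.3-fold higher number from compound 2 to compound 3 (0.11 log units; within the scatter). Compound 3 is expected near 50 nM, within 15 nM to 200 nM.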

Compound 3, half-maximal inhibitory concentration: 130 nM
The estimate for compound 3 lay 2.6-fold (0.41 log units) below the measured number, and the stated range covers the measured number.
By their numbers in this assay, from the lowest: compound 1; then compound 2; then compound 3.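

In this assay, (propanoyloxy)methyl at this position, on an aromatic carbon ortho to two fluoro groups, gives a 3.3-fold higher number from compound 2 to compound 3 (0.52 log units; beyond the scatter) in place of dimethylamino and a 17-fold higher number from compound 1 to compound 3 (1.23 log units; beyond the scatter) in place of amino. The three groups now stand in one order on the shared core: amino lowest, then dimethylamino, then (propanoyloxy)methyl. Nothing available explains this order.

On these data alone, it remains open whether the rise follows from the ester link or from the chain. A hydroxymethyl group, a carboxylic acid or a longer ester chain here could separate these readings.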